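Aryl substituent changes and whole-organism stomach inhibition

The compounds below may be only part of what the source reports. "The series", "measured", "known", "first", "only" and "open" are said of these compounds alone.

Measured so far:
compound 1 `Cc1ccccc1-c1oc2ccc(C(=O)O)cc2c(=O)c1O`: 15%
compound 2 `Cc1ccc(-c2oc3ccc(C(=O)O)cc3c(=O)c2O)cc1`: 6%
compound 3 `CCCCCCOc1ccc(-c2oc3ccc(C(=O)O)cc3c(=O)c2O)cc1`: -11%

In a functional assay on the whole organism (stomach) for inhibition, with Rattus norvegicus as the target, at a dose of 80 mg/kg (a higher number here means more inhibition at the dose given (going by the name of the read-out), a lower number less inhibition), compound 3 stands lowest of the three numbers, beyond the scatter from both others. The step that leads to it is a number 17 percentage points lower from compound 2 to compound 3 (beyond the scatter); before that, a number 9 percentage points lower from compound 1 to compound 2 (within the scatter).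

Compound 4 `O=C(O)c1ccc2oc(-c3ccc(Cl)cc3)c(O)c(=O)c2c1` is the next case. Relative to compound 3 the change is chloro in place of hexyloxy on an aromatic carbon.

Among the compounds with values here, the only step that bears on this is the one from compound 2 to compound 3, where the hexyloxy entered and the number fell modestly beyond the scatter. Compound 4 reverses that, replacing hexyloxy by a single chlorine on the same aromatic carbon. A step back upward is therefore expected, of roughly the size seen before: a number 16 percentage points higher from compound 3 to compound 4 (beyond the scatter).

Compound 4 is accordingly expected to give about 5% in this assay, within -14% to 24%.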

Compound 4, a percentage reported as inhibition, in the whole organism at one dose (the size of the read-out at that dose, not a potency): -19%
Compound 4: the middle estimate sits 24 percentage points above what was measured; the whole stated range lies above it.
By their numbers in this assay, from the lowest: compounds 4 and 3 (each within the scatter of the next); then compounds 2 and 1 (each within the scatter of the next).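

In this assay, the step of a number 8 percentage points lower from compound 3 to compound 4 (within the scatter) shows that the far smaller chloro group on this aromatic carbon does not separate from hexyloxy. Chloro in place of methyl gives a number 25 percentage points lower from compound 2 to compound 4 (beyond the scatter) and 4-chlorophenyl in place of 2-methylphenyl gives a number 34 percentage points lower from compound 1 to compound 4 (beyond the scatter) as the steps, so a low number at this carbon is not tied to the long hexyloxy chain. Nothing available explains why chloro and hexyloxy read alike here. From the compounds shown here alone, whether methoxy, a shorter ether than hexyloxy, or an amine on this carbon would give numbers nearer that of compound 2 stays open. Also open, going by these compounds, is how chloro would read with the 2-methylphenyl pattern of compound 1 replaced only in its substituent.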